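The source may hold more compounds than are shown below. What is called first, only, known or untested is meant among the compounds shown, and "the series" means these compounds.

In a functional assay on MCF7 cells (Homo sapiens) for inhibition, read by CCK-8 assay, with a stated time of 48 h (a higher number here means a weaker inhibitor of growth, a lower number a stronger inhibitor of growth), compound 1 (`Cc1ccccc1Nc1nc(NCc2ccco2)ncc1Cl`) reads > 100000 nM which is a limit of the assay and not a number. Compound 2 (`Cc1ccccc1Nc1nc(Nc2ccccn2)ncc1Cl`) reads 31400 nM and compound 3 (`Cc1ccccc1Nc1nc(Nc2ccc(N3CCN(C)CC3)cn2)ncc1Cl`) reads 5210 nM as the lower of the two numbers. Compound 4 (`CCN1CCN(c2ccc(Nc3ncc(Cl)c(Nc4ccccc4C)n3)nc2)CC1`) carries methyl in place of hydrogen on a saturated chain carbon bound to an amine nitrogen in a ring, so 4-methylpiperazin-1-yl becomes 4-ethylpiperazin-1-yl. The closest evidence is the modest 6.0-fold lower number from compound 2 to compound 3 (0.78 log units; beyond the scatter) on adding that whole group, while an at least 3.1-fold lower number from compound 1 to compound 2 (0.50 log units; beyond the scatter) concerns a change elsewhere. Neither step varies the group itself, so no step beyond the scatter is expected in this assay here. The estimated step is a 1.2-fold lower number from compound 3 to compound 4 (0.06 log units; within the scatter) in size. Compound 4 is expected near 4500 nM (estimated range 2000 nM to 10000 nM).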

Compound 4, concentration for 50% growth inhibition: > 100000 nM
Compound 4 ended at the assay's limit (the forecaster's own chance of this, stated with the estimate: 2%); at least 22-fold (1.34 log units) between middle value and limit.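

In this assay, the group itself now varies: 4-ethylpiperazin-1-yl in place of 4-methylpiperazin-1-yl gives an at least 19-fold higher number from compound 3 to compound 4 (1.28 log units; beyond the scatter), so one added methyl on a saturated chain carbon bound to an amine nitrogen in a ring is enough to lose the earlier gain. Against the compound without the group, 4-ethylpiperazin-1-yl gives an at least 3.1-fold higher number from compound 2 to compound 4 (0.50 log units; beyond the scatter), so the gain from 4-methylpiperazin-1-yl does not carry over to it. Compound 4 reads > 100000 nM, which is a limit of the assay and not a number, so both steps are lower bounds: the limit of > 100000 nM in this assay, at which 2 of the 4 values shown sit.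

Open, from the compounds shown here alone, is the true size of this loss. Also open, going by these compounds, is how unsubstituted piperazin-1-yl or a longer chain, as in 4-propylpiperazin-1-yl, would read.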